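The source may report more compounds than this note shows. Statements on the series, on what has been measured and on what is new or still open speak of the compounds shown alone.

For the measured compounds named here, in a functional assay on PANC-1 cells (Homo sapiens) for inhibition, read by MTT assay, with a stated time of 24 h, tested at 10 uM (a lower number here means less inhibition, a higher number more inhibition at the concentration tested (going by the name of the read-out)), the three compounds measured so far give low numbers. Compound 1 `COc1cccc(NC(=O)Oc2cc(=O)n(CCCO)c3c2CC(CC=C(C)C)C(C)(C)C3)c1` gives 0%, compound 2 `CC(C)=CCC/C(C)=C/COc1cc(=O)n(CCCO)c2c1CC(C/C=C(\C)CCC=C(C)C)C(C)(C)C2` gives 3.1%, and compound 3 `COc1cccc(NC(=O)Oc2cc(=O)n(CCCO)c3c2CC(C/C=C(\C)CCC=C(C)C)C(C)(C)C3)c1` gives 11.3%. Compound 3 holds the highest of the three numbers: its gap to compound 2, the nearest, is a number 8.2 percentage points higher from compound 2 to compound 3 (within the scatter), and its gap to compound 1, the furthest, is a number 11.3 percentage points higher from compound 1 to compound 3 (beyond the scatter), so only the distance to compound 1 counts as a real difference.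

Compound 4 `CC(C)=CCC/C(C)=C/CC1Cc2c(OC(=O)Nc3cccc(C(F)(F)F)c3)cc(=O)n(CCCO)c2CC1(C)C` is the unmeasured compound. It differs from compound 3 in one place: trifluoromethyl in place of methoxy on an aromatic carbon. Going by the values given here, no measured step changes a group on the phenyl ring of the carbamate. The step from compound 2 to compound 3, which replaces 3,7-dimethylocta-2,6-dien-1-yl on the ring oxygen with (3-methoxyphenyl)carbamoyl, is the only one touching this part of the molecule, and it stayed within the scatter. The step from compound 1 to compound 3, on the saturated chain carbon, concerns a distant position. The expectation for compound 4 is therefore a step of a number 0.7 percentage points higher from compound 3 to compound 4 (within the scatter) in this assay, no larger than the scatter in either direction. Compound 4 is estimated at 12%, within a range from 0% to 30%.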

Compound 4, a percentage reported as inhibition, at one concentration (the size of the read-out at that concentration, not a potency): 6.7%
For compound 4 the middle estimate is 5.3 percentage points above the measured one; the range from low to high includes it.
By their numbers in this assay, from the lowest: compounds 1, 2, 4 and 3 (each within the scatter of the next, the first and the last beyond it).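

Trifluoromethyl in place of methoxy is the first change shown on the phenyl ring of the carbamate, on an aromatic carbon meta to a large group, and in this assay it gives a number 4.6 percentage points lower from compound 3 to compound 4 (within the scatter). Four heavy atoms with no hydrogen-bond acceptor thus enter where two heavy atoms with one hydrogen-bond acceptor leave, and at this single tested concentration the read-out does not separate the two groups, so with the rest of the molecule held constant this position shows no measurable sensitivity to this exchange. Nothing available accounts for this outcome or shows whether it would hold at another concentration.

As far as these compounds go, it remains open whether a different group on this same aromatic carbon, such as an amine, a carboxylic acid or a nitrile, would move the read-out beyond the scatter, or whether an unsubstituted phenyl ring would read the same. Also open, from the compounds shown here alone, is whether the exchange of methoxy for trifluoromethyl would behave alike on the background of compound 1, which carries the shorter 3-methylbut-2-en-1-yl chain.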